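The compounds below may be only part of what the source reports. "The series", "measured", "known", "first", "only" and "open" are said of these compounds alone.

Working notes on the series. Three compounds have so far been run in an ADME assay on cells (Peritoneal macrophage, Mus musculus) for cytotoxicity, read by CCK-8 assay, with a stated time of 24 h; a higher number here means that more compound is tolerated, a lower number that less compound is tolerated. Compound 1 `COc1ccc(S(=O)(=O)N(CC(N)=O)c2ccc(N(CC(N)=O)S(=O)(=O)c3ccc(SCCN=C=S)cc3)c3ccccc23)cc1` serves as the point of reference. Compound 2 `COc1ccc(S(=O)(=O)N(CC(N)=O)c2ccc(N(CC(N)=O)S(=O)(=O)c3ccc(SCCCN=C=S)cc3)c3ccccc23)cc1` differs from it by a group of 4 heavy atoms (2 carbon, 1 nitrogen, 1 sulfur; no ring) in place of a group of 3 heavy atoms (1 carbon, 1 nitrogen, 1 sulfur; no ring), on a saturated chain carbon, two bonds along the chain from a sulfur. Compound 3 `COc1ccc(S(=O)(=O)N(CC(N)=O)c2ccc(N(CC(N)=O)S(=O)(=O)c3ccc(S(=O)(=O)CCCCN=C=S)cc3)c3ccccc23)cc1` differs from compound 1 in the core, the difference being (a group of 10 heavy atoms (5 carbon, 1 nitrogen, 2 oxygen, 2 sulfur; no ring) in place of a group of 6 heavy atoms (3 carbon, 1 nitrogen, 2 sulfur; no ring), on an aromatic carbon).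

In this assay compound 1 returns only a limit, > 10000 nM. Compound 2 likewise returns a limit, > 10000 nM. Compound 3 also returns a limit, > 10000 nM. All three readings sit at the limit of > 10000 nM in this assay, at which 3 of the 3 values shown sit, so none of the steps between them can be sized: a step that the two limits leave unreadable from compound 1 to compound 2, a step that the two limits leave unreadable from compound 1 to compound 3 and a step that the two limits leave unreadable from compound 2 to compound 3. The chain extension between compound 1 and compound 2 is thus not readable in this assay, and neither is the change of core.

Compound 4 `COc1ccc(S(=O)(=O)N(CC(N)=O)c2ccc(N(CC(N)=O)S(=O)(=O)c3ccc(S(=O)(=O)CCCCCN=C=S)cc3)c3ccccc23)cc1` has not yet been measured. Relative to compound 3 the change is a group of 4 heavy atoms (2 carbon, 1 nitrogen, 1 sulfur; no ring) in place of a group of 3 heavy atoms (1 carbon, 1 nitrogen, 1 sulfur; no ring), on a saturated chain carbon, four bonds along the chain from a sulfonyl sulfur. Within the data shown here, this is the same kind of change as the one between compound 1 and compound 2, not the same: there the entering group sits two bonds along the chain from a sulfur, here four bonds along the chain from a sulfonyl sulfur. The cores differ as described above for compound 1 and compound 3.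

The step from compound 3 to compound 4 is expected to be a step that the limit leaves unreadable from compound 3 to compound 4, an expectation that rests on the earlier unreadable step that the two limits leave unreadable from compound 1 to compound 2 and on (the limit of > 10000 nM in this assay, at which 3 of the 3 values shown sit). Compound 4 is estimated at 20000 nM in this assay, most likely again as a limit, within an expected range from 10000 nM to 60000 nM.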

Compound 4, half-maximal cytotoxic concentration: > 10000 nM
Compound 4 ended at the assay's limit (the forecaster's own chance of this, stated with the estimate: 85%); the middle value lies beyond the limit too.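

In this assay compound 4 gives > 10000 nM, again a limit. None of the steps linking compound 4 to compound 1, compound 2 and compound 3 can be read, and the series remains at a single reading: the limit of > 10000 nM in this assay, at which 4 of the 4 values shown sit. The compounds shown leave open at what concentration any of them becomes cytotoxic, and whether chain length or the change of core alters that concentration.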